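The compounds below may be only part of what the source reports. "The series", "measured", "known", "first", "only" and "open" are said of these compounds alone.

Working notes on the series. In a functional assay on BGC-823 cells (Homo sapiens) for antiproliferative activity, read by MTT assay, with a stated time of 24 h (on this read-out lower numbers stand for stronger inhibition and higher numbers for weaker inhibition), compound 1 `c1ccc(CSc2nnc(-c3ccc4c(c3)OCCO4)n2-c2ccccc2)cc1` gives 73400 nM and compound 2 `Fc1ccccc1CSc1nnc(-c2ccc3c(c2)OCCO3)n1-c1ccccc1` gives 18600 nM. Going by the values given here, compound 2 therefore holds the lower of the two numbers so far, and it is the reference point for the next change.

Compound 3 `Fc1cccc(F)c1CSc1nnc(-c2ccc3c(c2)OCCO3)n1-c1ccccc1` is reached from compound 2 by fluoro in place of hydrogen on an aromatic carbon. This is fluoro in place of hydrogen on an aromatic carbon, and it turns 2-fluorobenzyl into 2,6-difluorobenzyl.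

Among the compounds with values here, only one measured step bears on this change: a 3.9-fold lower number from compound 1 to compound 2 (0.60 log units; beyond the scatter). It is the same kind of replacement, on the same ring, and it lowered the number by a modest amount. Within the data shown here, one step is thin support, and no measurement yet shows whether a second fluoro repeats the effect of the first. In this assay, a further drop is therefore expected, but a smaller one that may not clear the scatter.

The expected step is a 1.7-fold lower number from compound 2 to compound 3 (0.23 log units; within the scatter). For compound 3, the estimated value is 11000 nM, with an expected range of 4000 nM to 28000 nM.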

Compound 3, half-maximal inhibitory concentration: 84200 nM
The estimate for compound 3 lay 7.7-fold (0.88 log units) below the measured number, and the stated range ends below it.
By their numbers in this assay, from the lowest: compound 2; then compounds 1 and 3 (each within the scatter of the next).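

In this assay the second fluoro does not repeat the effect of the first: the same kind of replacement that gave a 3.9-fold lower number from compound 1 to compound 2 (0.60 log units; beyond the scatter) now gives a 4.5-fold higher number from compound 2 to compound 3 (0.66 log units; beyond the scatter) on going from 2-fluorobenzyl to 2,6-difluorobenzyl. The effect of fluoro on this ring therefore changes direction with what the ring already carries, so the first step cannot be read as a general benefit of adding fluoro. The full change from benzyl to 2,6-difluorobenzyl amounts to a 1.1-fold higher number from compound 1 to compound 3 (0.06 log units; within the scatter) and leaves the two end compounds within the scatter of each other, so the advantage held by compound 2 does not survive the added fluoro, and nothing at hand explains this reversal.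

Still open, going by these compounds, is whether the advantage of compound 2 belongs to fluoro itself or would also appear with chloro, methyl or methoxy on the same ring. Also open, on these data alone, is whether a second group other than fluoro, such as a hydroxyl or an amine, would be tolerated alongside the 2-fluorobenzyl pattern.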